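The compounds below may be only part of what the source reports. "The series", "measured", "known", "first", "only" and "open" are said of these compounds alone.

Series notes on the shared core. Compound 1 `Cc1ccc(S(=O)(=O)NCc2ccc(CNC(=O)c3ccncc3)cc2)cc1` is the reference point. In an assay on MDA-MB-231 cells for binding affinity to C-X-C chemokine receptor type 4 (Homo sapiens), read by immunofluorescence and microscopy, with stated times of 10 min and 30 min (on this read-out higher numbers stand for an effect only at larger amounts of compound and lower numbers for an effect already at smaller amounts), compound 1 gives 10 nM. Compound 3 `O=C(NCc1ccc(CNS(=O)(=O)c2ccccc2)cc1)c1cccnc1` gives 10 nM in this assay, level with compound 1 at the digits reported, and together these two hold the lowest numbers of the three measured compounds. Going by the values given here, compound 2 `Cc1ccc(S(=O)(=O)NCc2ccc(CNC(=O)c3ccccc3F)cc2)cc1` gives 1000 nM in this assay; the single measured step, a 100-fold higher number from compound 1 to compound 2 (2.00 log units; beyond the scatter), is large and beyond the scatter.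

Compound 4 `Cc1ccc(S(=O)(=O)NCc2ccc(CNC(=O)c3ccccc3Cl)cc2)cc1` is not yet measured in this assay. It differs from compound 1 as follows: 2-chlorophenyl in place of pyridin-4-yl on a carbonyl carbon. The change is closely related to that from compound 1 to compound 2: in both, a six-membered aromatic ring with one hetero atom gives way to a ring of carbon only carrying a halogen, and the difference between them is 2-chlorophenyl in place of 2-fluorophenyl. Among the compounds with values here, no measured step from 2-fluorophenyl to 2-chlorophenyl is available in this set, so the step to compound 2 is the only precedent and it bears directly. Given a 100-fold higher number from compound 1 to compound 2 (2.00 log units; beyond the scatter), compound 4 is expected to show a 100-fold higher number from compound 1 to compound 4 (2.00 log units; beyond the scatter). Compound 4 is therefore estimated at about 1000 nM in this assay, within a range of 200 nM to 5000 nM.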

Compound 4, effective concentration (reported as EC, without a stated level of effect): 10 nM
Estimate against measurement, compound 4: 100-fold (2.00 log units) above, and the stated range ends above it.
By their numbers in this assay, from the lowest: compounds 1, 3 and 4 (each within the scatter of the next); then compound 2.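

In this assay, 2-chlorophenyl in place of pyridin-4-yl on a carbonyl carbon gives no change at the digits printed from compound 1 to compound 4 (within the scatter) and so shows that, on the core of compound 1, this place can hold a ring of carbon only with no hydrogen-bond acceptor, which compound 2 alone gave no sign of. The outcome at this place turns on the halogen in this pair: chloro in place of fluoro on an aromatic carbon gives a 100-fold lower number from compound 2 to compound 4 (2.00 log units; beyond the scatter) and so the high number of compound 2 cannot be read as the price of losing pyridin-4-yl alone. No measurement at hand gives a reason for this large gap between the two halogens.

As far as these compounds go, with only these two halogen-bearing rings on the shared core, it remains open whether compound 2 or compound 4 is the exception, and a plain phenyl, 2-bromophenyl or 2-methylphenyl on the same carbonyl carbon would bear on that. Compound 3 differs from the others in more than one place, so what its separate changes contribute cannot be read from these compounds.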